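A Dihydroxyphenyl Group Replaces Dichlorophenyl in Compound 2

This account rests on a few compounds, and the source may have more. Where it says the series, first, only, none or still open, it means among the compounds named here.

Three compounds sharing one core were taken into a functional assay on MCF7 cells (Homo sapiens) for cytotoxicity, read by MTT assay, with a stated time of 72 h (on this read-out lower numbers stand for stronger inhibition and higher numbers for weaker inhibition), and only one of them yielded a number. There, compound 1 (`N#Cc1ccc(/C=N/NC(=O)Nc2cc3c(Nc4ccc(F)c(Cl)c4)ncnc3cc2O[C@H]2CCOC2)cc1`) is recorded as "not determined" (no result reported). Compound 3 (`COc1ccc(/C=N/NC(=O)Nc2cc3c(Nc4ccc(F)c(Cl)c4)ncnc3cc2O[C@H]2CCOC2)c(OC)c1OC`) gives 33800 nM. Compound 2 (`O=C(N/N=C/c1cccc(Cl)c1Cl)Nc1cc2c(Nc3ccc(F)c(Cl)c3)ncnc2cc1O[C@H]1CCOC1`) is recorded as "not active" (no number reported), so it has no single number and cannot be ranked numerically against compound 3.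

The next compound to be tested, compound 4 (`O=C(N/N=C/c1ccc(O)cc1O)Nc1cc2c(Nc3ccc(F)c(Cl)c3)ncnc2cc1O[C@H]1CCOC1`), starts from compound 2 and carries 2,4-dihydroxyphenyl in place of 2,3-dichlorophenyl on a carbon with a double bond to nitrogen. For the measured compounds named here, no measured step shows what such a change does. Going by the values given here, a modest step toward stronger inhibition is expected in this assay, or none at all, and the only guide to its scale is compound 3 at 33800 nM. Compound 4 may also fail to give a number. If it does give one, compound 4 is estimated at 25000 nM, with an expected range of 6000 nM to 80000 nM.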

Compound 4, half-maximal inhibitory concentration: 5350 nM
For compound 4 the middle estimate is 4.7-fold (0.67 log units) above the measured one, outside the stated range (below it).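

Changing the group on a carbon with a double bond to nitrogen does move the number in this assay: 2,4-dihydroxyphenyl in place of 2,3,4-trimethoxyphenyl brings a 6.3-fold lower number from compound 3 to compound 4 (0.80 log units; beyond the scatter), a step beyond the usual scatter. Compound 2, with 2,3-dichlorophenyl, is recorded as not active, whereas compound 4 gives 5350 nM, although the step between these two cannot be read as a number. Nothing at hand accounts for either difference.

As far as these compounds go, it remains open whether both hydroxyl groups of 2,4-dihydroxyphenyl are needed, or whether a single one, as in 4-hydroxyphenyl, would give a similar number. The compounds shown also leave unknown how a phenyl ring bearing an amine or a carboxylic acid would read at this position.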